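The source may report more compounds than this note shows. Statements on the series, on what has been measured and on what is new or still open speak of the compounds shown alone.

Compound 1, `CCCC[C@H](NC(=O)[C@H](CCCCN)NC(=O)[C@H](CCCNC(=N)N)NC(=O)c1ccccc1)C(N)=O`: "impermeable" (no number reported)
Compound 2, `CCCC[C@H](NC(=O)[C@H](CCCN)NC(=O)[C@H](CCCNC(=N)N)NC(=O)c1ccc(/C=C2\SC(=O)N(Cc3ccccc3)C2=O)cc1)C(N)=O`: "impermeable" (no number reported)
Compound 3, `CCCC[C@H](NC(=O)[C@H](CCCCN)NC(=O)[C@H](CCCNC(=N)N)NC(=O)c1cccc(/C=C2\SC(=O)N(C3CCCC3)C2=O)c1)C(N)=O`: 1.9 10^-6 cm/s

In an ADME assay for permeability, using PAMPA (a lower number here means that the compound crosses the layer more slowly, a higher number that the compound crosses the layer faster), compound 1 gives "impermeable" (no number reported), so no number stands for it. Compound 2 is a second entry of the same kind, reported in this assay as "impermeable" (no number reported). Only compound 3, in this assay, has a number, and it gives 1.9 10^-6 cm/s. Compound 1 therefore cannot be placed on a scale against compound 3; it stands without a number, and a single measured figure is all there is.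

Compound 4, `CCCC[C@H](NC(=O)[C@H](CCCCN)NC(=O)[C@H](CCCNC(=N)N)NC(=O)c1ccc(/C=C2\SC(=S)N(CCCC)C2=O)cc1)C(N)=O`, is not yet measured. It differs from compound 1 in one place: a group of 12 heavy atoms (8 carbon, 1 nitrogen, 1 oxygen, 2 sulfur; one five-membered non-aromatic ring with 2 hetero atoms) in place of a hydrogen atom, on an aromatic carbon. For the measured compounds named here, no step between two measured compounds is recorded, so the size of the step in this assay cannot be taken from the data. The expectation is a step upward, beyond the scatter, from a compound without a number to a small measurable value, resting on compound 3 and its 1.9 10^-6 cm/s. Compound 4 is estimated in this assay at 1 10^-6 cm/s, between 0.3 10^-6 cm/s and 3 10^-6 cm/s.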

Compound 4, apparent permeability: 1.61 10^-6 cm/s
For compound 4 the middle estimate is 1.6-fold (0.21 log units) below the measured one, within the range that was stated.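

In this assay, for the compounds shown here, compound 1 has no number and compound 4 has one, so no step from compound 1 to compound 4 can be read. Nothing measured here speaks to a cause. The compounds shown leave open how far the entering group alone shifts the read-out in this assay on a numerical scale.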